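The source may report more compounds than this note shows. Statements on the series, on what has been measured and on what is new or still open speak of the compounds shown alone.

Compound 1, `CC(C)COC(=O)N1CCN(C(=O)c2nc(Nc3cc(C4CC4)[nH]n3)c3cc(Cl)ccc3n2)C[C@H]1C`: 46.9%
Compound 2, `C[C@@H]1CN(C(=O)c2nc(Nc3cc(C4CC4)[nH]n3)c3cc(Cl)ccc3n2)CCN1C(=O)OCc1ccccc1`: 96%
Compound 3, `COC(=O)N1CCN(C(=O)c2nc(Nc3cc(C4CC4)[nH]n3)c3cc(Cl)ccc3n2)C[C@H]1C`: 98.5%

In an assay for inhibition of serine/threonine-protein kinase PAK 4 (Homo sapiens), read by FRET and Z'-LYTE, with a stated time of 60 min, tested at 50 uM, in the presence of a further agent that is not named here (on this read-out higher numbers stand for a stronger effect at the one concentration tested and lower numbers for a weaker effect), compound 3 gives the highest of the three numbers; compound 2 lies within the scatter of it, while compound 1 sits far lower. Compound 4, `CC(C)OC(=O)N1CCN(C(=O)c2nc(Nc3cc(C4CC4)[nH]n3)c3cc(Cl)ccc3n2)C[C@H]1C`, differs from compound 3 in one place: isopropyl in place of methyl on an oxygen next to a carbonyl group.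

For the measured compounds named here, two measured steps touch the same oxygen. Putting hydrogen in place of isopropyl on the saturated chain carbon bound to that oxygen gave a number 51.6 percentage points higher from compound 1 to compound 3 (beyond the scatter), and the step of a number 2.5 percentage points higher from compound 2 to compound 3 (within the scatter) shows phenyl and hydrogen at that carbon giving numbers within the scatter. Going by the values given here, compound 4 carries isopropyl directly on the oxygen, a smaller group than the one compound 1 carries but larger than the methyl of compound 3, so the loss seen for compound 1 is the nearest guide. A fall beyond the scatter, though smaller than that for compound 1, is expected, giving a number 20.5 percentage points lower from compound 3 to compound 4 (beyond the scatter). For compound 4 the value in this assay is estimated at 78%, with a range from 45% to 98%.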

Compound 4, a percentage reported as inhibition, at one concentration (the size of the read-out at that concentration, not a potency): 91.2%
Compound 4: the middle estimate sits 13.2 percentage points below what was measured; low and high end bracket the measured number.
By their numbers in this assay, from the lowest: compound 1; then compounds 4, 2 and 3 (each within the scatter of the next).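

Isopropyl in place of methyl on an oxygen next to a carbonyl group gives a number 7.3 percentage points lower from compound 3 to compound 4 (within the scatter), and isopropyl in place of benzyl gives a number 4.8 percentage points lower from compound 2 to compound 4 (within the scatter), so in this assay the methyl, isopropyl and benzyl carbamates cannot be told apart. Compound 1 is the one that goes against this, with isopropyl in place of isobutyl giving a number 44.3 percentage points higher from compound 1 to compound 4 (beyond the scatter), so the loss belongs to isobutyl alone among these four groups and not to every group larger than methyl. Nothing available explains why isobutyl stands apart.

Going by these compounds, whether a tert-butyl group or a longer chain such as n-pentyl on this oxygen would keep the number high or lose it as isobutyl does remains open. A reading at one concentration also leaves open whether compound 2, compound 3 and compound 4 would show a stronger or weaker effect than one another at any other concentration.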